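Replacing a Bulky Side Chain with a Short Diol

This account rests on a few compounds, and the source may have more. Where it says the series, first, only, none or still open, it means among the compounds named here.

Of the compounds shown here, three sharing one core have been measured in a functional assay on HCT-116 cells (Homo sapiens) for antiproliferative activity, read by sulforhodamine B assay, with a stated time of 72 h; on this read-out lower numbers stand for stronger inhibition and higher numbers for weaker inhibition. Compound 1, `Cn1ncc(Cl)c1-c1cc(C(=O)N[C@@H]2CNCC[C@H]2c2ccc(C(F)(F)F)cc2)oc1Cl`, gives 280 nM. Compound 2, `Cn1ncc(Cl)c1-c1cc(C(=O)N[C@@H]2CN[C@H](CCO)C[C@H]2c2ccc(F)c(F)c2)oc1Cl`, gives 360 nM. Compound 3, `Cn1ncc(Cl)c1-c1cc(C(=O)N[C@@H]2CN[C@H](CCN3CCC(O)CC3)C[C@H]2c2ccc(Cl)c(Cl)c2)oc1Cl`, gives 13700 nM, the highest of the three numbers and therefore the weakest inhibitor of the set, well beyond the scatter from both others.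

Compound 4, `Cn1ncc(Cl)c1-c1cc(C(=O)N[C@@H]2CN[C@H](CC(O)CO)C[C@H]2c2ccc(Cl)c(Cl)c2)oc1Cl`, has not yet been measured. It differs from compound 3 in one place: 1,2-dihydroxyethyl in place of (4-hydroxypiperidin-1-yl)methyl on a saturated chain carbon bound to a saturated ring carbon. The side chain on the saturated ring carbon thus becomes much smaller, and compound 2, which carries a short hydroxyethyl chain in a similar position, sits at a far lower number than compound 3.

Compound 4 is therefore expected to show a clear drop in this assay , with the step of a 20-fold lower number from compound 3 to compound 4 (1.29 log units; beyond the scatter) estimated to lie beyond the scatter, although the dichloro substitution it shares with compound 3 leaves some doubt. The estimate for compound 4 is 700 nM, within a range from 150 nM to 3500 nM.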

Compound 4, half-maximal inhibitory concentration: 1110 nM
Estimate against measurement, compound 4: 1.6-fold (0.20 log units) below, and the stated range covers the measured number.
By their numbers in this assay, from the lowest: compounds 1 and 2 (each within the scatter of the next); then compound 4; then compound 3.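

Replacing (4-hydroxypiperidin-1-yl)methyl with 1,2-dihydroxyethyl on a saturated chain carbon bound to a saturated ring carbon gives a 12-fold lower number from compound 3 to compound 4 (1.09 log units; beyond the scatter) in this assay. The earlier compounds shown here differ from one another in more than one place, so none of them could tie a change in the number to this side chain alone, whereas this pair, identical elsewhere, shows that the side chain by itself moves the read-out by far more than the scatter. No measurement shown separates the loss of the ring, the loss of the nitrogen and the added hydrogen-bond donor as the source of this step.

Going by these compounds, how a short open-chain amine, a carboxylic acid or a longer diol chain would read at this place remains open. So does whether a cyclohexyl ring, which has no nitrogen, would give a number closer to that of compound 3 or compound 4.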